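The source may hold more compounds than are shown below. What is called first, only, known or untested is meant among the compounds shown, and "the series" means these compounds.

Among the measured compounds shown here, compound 1 `NS(=O)(=O)c1ccc(Nc2ncc(F)c(Nc3nc4ccc(Cl)cc4s3)n2)cc1` is the one member of this small set with a numerical value: in a functional assay on MCF7 cells (Homo sapiens) for antiproliferative activity, read by MTT assay, with a stated time of 48 h (a lower number here means a stronger inhibitor, a higher number a weaker inhibitor), compound 1 gives 8340 nM. Compound 2 `CS(=O)(=O)c1ccc(Nc2ncc(F)c(Nc3nc4ccc(Cl)cc4s3)n2)cc1` reaches only the limit of this assay, > 50000 nM. Compound 3 `COc1ccc2nc(Nc3nc(Nc4ccc(S(N)(=O)=O)cc4)ncc3F)sc2c1` likewise reaches only a limit, > 50000 nM. The change methyl in place of amino on a sulfonyl sulfur thus produces an at least 5.9-fold higher number from compound 1 to compound 2 (0.77 log units; beyond the scatter), and the change methoxy in place of chloro on an aromatic carbon produces an at least 5.9-fold higher number from compound 1 to compound 3 (0.77 log units; beyond the scatter). Compound 4 `COc1ccc2nc(Nc3nc(Nc4ccc(S(C)(=O)=O)cc4)ncc3F)sc2c1` has not been measured; it differs from compound 3 by methyl in place of amino on a sulfonyl sulfur, the same change that separates compound 1 from compound 2. Since compound 3 already sits at the limit of > 50000 nM in this assay, at which 2 of the 3 values shown sit, and that change cost activity once, compound 4 is expected to give 90000 nM. For compound 4 the expected step is a step that the limit leaves unreadable from compound 3 to compound 4, resting on an at least 5.9-fold higher number from compound 1 to compound 2 (0.77 log units; beyond the scatter).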

Compound 4, half-maximal inhibitory concentration: 5850 nM
Compound 4: middle estimate off by 15-fold (1.19 log units), on the high side; measured number below the stated range.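

In this assay, methyl in place of amino on a sulfonyl sulfur gives an at least 8.5-fold lower number from compound 3 to compound 4 (0.93 log units; beyond the scatter), so this change does not keep its direction from one core to the other: the same change on two cores in this assay, an at least 5.9-fold higher number (0.77 log units; beyond the scatter) from compound 1 to compound 2 and an at least 8.5-fold lower number (0.93 log units; beyond the scatter) from compound 3 to compound 4, at least 51-fold (1.70 log units) apart, beyond the scatter of two such steps

Methoxy in place of chloro on an aromatic carbon gives an at least 8.5-fold lower number from compound 2 to compound 4 (0.93 log units; beyond the scatter), and this change does not keep its direction either: the same change on two cores in this assay, an at least 5.9-fold higher number (0.77 log units; beyond the scatter) from compound 1 to compound 3 and an at least 8.5-fold lower number (0.93 log units; beyond the scatter) from compound 2 to compound 4, at least 51-fold (1.70 log units) apart, beyond the scatter of two such steps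

Each of these steps rests on a limit of the assay, so their true sizes remain unknown, and two cores show neither why the direction differs nor any rule for the wider series.

The compounds shown leave open how bromo or ethoxy on that aromatic carbon would behave. They also leave open whether ethyl or dimethylamino on the sulfonyl sulfur would follow either core.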